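Swapping the amide aryl group on a bis-benzylic scaffold

The source may hold more compounds than are shown below. What is called first, only, known or untested is meant among the compounds shown, and "the series" means these compounds.

Of the compounds shown here, three with a shared core have been measured in an assay on MDA-MB-231 cells for binding affinity to C-X-C chemokine receptor type 4 (Homo sapiens), read by immunofluorescence and microscopy, with stated times of 10 min and 30 min; a lower number here means that less compound is needed, a higher number that more compound is needed for the effect. Compound 1 `O=C(NCc1ccc(CNS(=O)(=O)c2ccccc2)cc1)c1cccc(F)c1` gives 100 nM in this assay. Among the measured compounds shown here, compound 3 `O=C(NCc1ccc(CNS(=O)(=O)c2ccccc2)cc1)c1ccc([N+](=O)[O-])cc1` gives 100 nM in this assay, and the only step between measured compounds, no change at the digits printed from compound 1 to compound 3 (within the scatter), shows that exchanging one aromatic group on the carbonyl carbon for another left the number where it was. Compound 2 `COc1ccc(C(=O)NCc2ccc(CNS(=O)(=O)c3ccc(C)cc3)cc2)cc1` gives 100 nM in this assay, so it stands level with compound 1 and compound 3, with no difference beyond the scatter in either direction.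

The compound still to be measured is compound 4 `Cc1ccc(S(=O)(=O)NCc2ccc(CNC(=O)c3ccccc3F)cc2)cc1`. It differs from compound 2 in one place: 2-fluorophenyl in place of 4-methoxyphenyl on a carbonyl carbon. For the measured compounds named here, since this is again an exchange of one aromatic group for another on the carbonyl carbon, the one comparable step, from compound 1 to compound 3, is the only guide, and it showed no change beyond the scatter. The expectation is therefore a step of no change at the digits printed from compound 2 to compound 4 (within the scatter), that is, no shift beyond the scatter in this assay. On that basis compound 4 is estimated to give 100 nM in this assay, with a likely range from 40 nM to 250 nM.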

Compound 4, effective concentration (reported as EC, without a stated level of effect): 1000 nM
Compound 4: middle estimate off by 10-fold (1.00 log units), on the low side, outside the stated range (above it).
By their numbers in this assay, from the lowest: compounds 1, 2 and 3 (each within the scatter of the next); then compound 4.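

this assay now records a 10-fold higher number from compound 2 to compound 4 (1.00 log units; beyond the scatter) when 2-fluorophenyl replaces 4-methoxyphenyl on a carbonyl carbon, so more compound is needed for the effect after this exchange. The earlier step of no change at the digits printed from compound 1 to compound 3 (within the scatter) could have suggested that this position accepts any aromatic group, but the new step shows that the choice of aromatic group here can matter, even though the two groups differ little in the counts of heavy atoms and both keep one six-membered aromatic ring. The two steps stand on slightly different versions of the shared core, and nothing shown here gives a measured reason for the rise.

Among the compounds shown here, the single exchange removes the methoxy group and brings in the fluorine at once, so these compounds cannot tell whether losing the first or gaining the second accounts for the higher number. A plain phenyl group, a 4-fluorophenyl group or a 2-methoxyphenyl group on the same carbonyl carbon, with the rest of compound 2 kept, would pull those two parts of the change apart.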